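Hexylamino for chloro on the core of compound 2

This account rests on a few compounds, and the source may have more. Where it says the series, first, only, none or still open, it means among the compounds named here.

Compound 2 `OC[C@H]1OC(n2cnc3c(Cl)nccc32)[C@H](O)[C@@H]1O` stands highest among the three measured compounds: in a functional assay (Homo sapiens) for inhibition of Nucleic Acid, tested at 100 uM (on this read-out higher numbers stand for more inhibition at the one concentration tested (going by the name of the read-out) and lower numbers for less inhibition), compound 2 gives 76%. Compound 1 `CCNc1nccc2c1ncn2C1O[C@H](CO)[C@@H](O)[C@H]1O` gives 4% in this assay, and compound 3 `[O-][n+]1ccc2[nH]cnc2c1` gives 3% in this assay. Among the measured compounds shown here, the one step between single-point neighbours is a number 72 percentage points higher from compound 1 to compound 2 (beyond the scatter), a large gain for chloro over ethylamino on the aromatic carbon.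

Compound 4 `CCCCCCNc1nccc2c1ncn2C1O[C@H](CO)[C@@H](O)[C@H]1O` is not yet measured. Its change from compound 2 is hexylamino in place of chloro on an aromatic carbon. This is the mirror of the measured step, with a longer chain entering where ethylamino stood in compound 1: an alkylamino group again replaces the chloro on the aromatic carbon. For the measured compounds named here, the only bearing step is the large one from compound 1 to compound 2, so a drop of similar size is expected in this assay when chloro leaves. From the compounds shown here alone, the longer hexylamino chain is untested, so the range is kept wide.

For compound 4 the expected step is a number 64 percentage points lower from compound 2 to compound 4 (beyond the scatter) in this assay. Compound 4 is estimated at 12%, within 0% to 40%, because compound 1 with ethylamino gave 4%.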

Compound 4, a percentage reported as inhibition, at one concentration (the size of the read-out at that concentration, not a potency): 8%
For compound 4 the middle estimate is 4 percentage points above the measured one; measured number inside the range.
By their numbers in this assay, from the lowest: compounds 3, 1 and 4 (each within the scatter of the next); then compound 2.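

In this assay the large loss on leaving chloro now holds for a second alkylamino group: there is a number 68 percentage points lower from compound 2 to compound 4 (beyond the scatter) on this aromatic carbon, so the low number is not confined to ethylamino. The two alkylamino compounds cannot be told apart, with a number 4 percentage points higher from compound 1 to compound 4 (within the scatter) for butyl in place of hydrogen on the chain, so across these two chain lengths the extension adds no measurable inhibition at this concentration. No measurement at hand bears on why chloro and the alkylamino groups stand so far apart.

From the compounds shown here alone, it remains open whether the high number belongs to chloro itself or would also be held by bromo, methoxy or an unsubstituted amine on the same carbon. Going by these compounds, it is equally open whether a chain ending in a hydroxyl or a carboxylic acid would stay as low as hexylamino.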